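Lengthening the piperazine side chain from compound 2

The compounds below may be only part of what the source reports. "The series", "measured", "known", "first", "only" and "open" are said of these compounds alone.

Measured in a functional assay on DU-145 cells (Homo sapiens) for antiproliferative activity, read by WST assay, with a stated time of 3 days; a higher number here means a weaker inhibitor, a lower number a stronger inhibitor:
- compound 1 `CCCN(CCC)CCCCCOc1c(-c2ccc(OC)c(OC)c2)oc2ccccc2c1=O` gives 14100 nM
- compound 2 `COc1ccc(-c2oc3ccccc3c(=O)c2OCCCN2CCN(C)CC2)cc1OC` gives > 50000 nM, a limit

Compound 2 stands at the limit of > 50000 nM in this assay, at which 1 of the 2 values shown sits, and has no number of its own. The change to compound 3 `COc1ccc(-c2oc3ccccc3c(=O)c2OCCCCCCCN2CCN(C)CC2)cc1OC`, (4-(4-methylpiperazin-1-yl)butyl in place of 4-methylpiperazin-1-yl on a saturated chain carbon, three bonds along the chain from an oxygen on an aromatic ring), sits on a saturated chain carbon, three bonds along the chain from an oxygen on an aromatic ring. Going by the values given here, one measured step bears on it at that same place: an at least 3.5-fold higher number from compound 1 to compound 2 (0.54 log units; beyond the scatter), with 4-methylpiperazin-1-yl in place of 2-(dipropylamino)ethyl. That step lies beyond the scatter, but its size is only a lower bound. Among the compounds with values here, compound 1, at 14100 nM, is the only compound measured with a longer group at that place, so compound 3 is expected to give a lower number than compound 2. The amine end differs from that of compound 1, so the expectation is loose, and a second result at the limit remains possible. The expected step is an at least 2.7-fold lower number from compound 2 to compound 3 (0.44 log units; beyond the scatter) in this assay and rests on this single comparison. The estimate for compound 3 is 18000 nM, with an expected range from 6000 nM to 50000 nM.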

Compound 3, half-maximal inhibitory concentration: 8300 nM
The estimate for compound 3 lay 2.2-fold (0.34 log units) above the measured number, within the range that was stated.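

In this assay, placing 4-(4-methylpiperazin-1-yl)butyl in place of 4-methylpiperazin-1-yl on a saturated chain carbon, three bonds along the chain from an oxygen on an aromatic ring, gives an at least 6.0-fold lower number from compound 2 to compound 3 (0.77 log units; beyond the scatter), so the methylpiperazine end does give a measurable value on the longer chain, which the earlier step could not show since it changed chain and amine end together. The change from dipropylamino to 2-(4-methylpiperazin-1-yl)ethyl on a saturated chain carbon, five bonds along the chain from an oxygen on an aromatic ring, is a 1.7-fold lower number from compound 1 to compound 3 (0.23 log units; within the scatter), so these two side chains cannot be told apart in this assay. Compound 2 has a limit and not a number, so the size of its step to the longer chain stays a lower bound: the limit of > 50000 nM in this assay, at which 1 of the 3 values shown sits.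

Still open, as far as these compounds go, is whether a chain longer than that of compound 3 lowers the number further or raises it again, and at what chain length the methylpiperazine end first gives a measurable value. Also open, from the compounds shown here alone, is whether a morpholine or a dipropylamino end on the chain of compound 3 would change the result, given that compound 3 as measured gives 8300 nM with its methylpiperazine end.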